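The compounds below may be only part of what the source reports. "The series", "measured", "known", "first", "only" and "open" are said of these compounds alone.

Working notes on the series in a functional assay on A549 cells (Homo sapiens) for cytotoxicity; a lower number here means that less compound is needed, a higher number that more compound is needed for the effect: compound 1 (`COC1=C(C)C(=O)/C(=C(O)/C=C/c2ccccc2OC)C(=O)C1(C)C`) gives 2.4 ug/mL, compound 2 (`COC1=C(C)C(=O)/C(=C(O)/C=C/c2ccc(C)cc2)C(=O)C1(C)C`) gives 4.3 ug/mL and compound 3 (`CCc1ccc(/C=C/C(O)=C2/C(=O)C(C)=C(OC)C(C)(C)C2=O)cc1`) gives 6.1 ug/mL. Compound 3 stands at the upper end of this narrow range, with a 2.5-fold higher number from compound 1 to compound 3 (0.41 log units; beyond the scatter) and, within the scatter, a 1.4-fold higher number from compound 2 to compound 3 (0.15 log units; within the scatter).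

The next change is thiophen-2-yl in place of 4-ethylphenyl on a double-bonded chain carbon bound to a double-bonded chain carbon, which leads to compound 4 (`COC1=C(C)C(=O)/C(=C(O)/C=C/c2cccs2)C(=O)C1(C)C`), with thiophen-2-yl in place of 4-ethylphenyl on a double-bonded chain carbon bound to a double-bonded chain carbon. For the measured compounds named here, no measured compound carries thiophen-2-yl, so the only guides are the earlier exchanges at this place, a 1.8-fold higher number from compound 1 to compound 2 (0.25 log units; within the scatter) and a 2.5-fold higher number from compound 1 to compound 3 (0.41 log units; beyond the scatter). Both are small, and neither involves a five-membered aromatic ring. No step beyond the scatter is therefore expected in this assay, with only a slight lean towards a lower number given the upper-end position of compound 3. The expected step is a 1.5-fold lower number from compound 3 to compound 4 (0.18 log units; within the scatter). For compound 4 the estimate is 4 ug/mL, with an expected range of 1.6 ug/mL to 10 ug/mL.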

Compound 4, concentration for half-maximal effect: 4.5 ug/mL
The estimate for compound 4 lay 1.1-fold (0.05 log units) below the measured number; low and high end bracket the measured number.
By their numbers in this assay, from the lowest: compounds 1, 2, 4 and 3 (each within the scatter of the next, the first and the last beyond it).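

In this assay thiophen-2-yl, the first five-membered aromatic ring at this place, stays within the scatter of all three six-membered aromatic groups it is compared with (a 1.4-fold lower number from compound 3 to compound 4 (0.13 log units; within the scatter)) and (a 1.0-fold higher number from compound 2 to compound 4 (0.02 log units; within the scatter)) and (a 1.9-fold higher number from compound 1 to compound 4 (0.27 log units; within the scatter)). This place therefore accepts a ring with a sulfur atom and 5 heavy atoms in place of the 8 of 4-ethylphenyl without a step beyond the scatter, and compound 4 sits within the scatter of compound 1, whereas compound 3 does not. No measured evidence available here gives a reason for this flat response.

The compounds shown leave open whether this narrow range persists with an amine or a carboxylic acid on the aromatic ring. They also leave open whether a saturated group such as cyclohexyl at this place would give a step beyond the scatter.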